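The compounds below may be only part of what the source reports. "The series", "measured", "known", "first", "only" and "open" are said of these compounds alone.

Measured so far in a functional assay on HUVEC cells (Homo sapiens) for antiproliferative activity; on this read-out higher numbers stand for weaker inhibition of growth and lower numbers for stronger inhibition of growth:
- compound 1 `COc1cc(/C=C/C(=O)Nc2ccc(NC(=O)[C@@H](O)[C@H](N)CC3CCCCC3)cc2C)cc(OC)c1OC`: 1800 nM
- compound 2 `COc1cc(/C=C/C(=O)Nc2ccc(NC(=O)[C@@H](O)[C@H](N)CCc3ccccc3)cc2)cc(OC)c1OC`: 850 nM
- compound 3 `COc1cc(NC(=O)/C=C/c2cc(OC)c(OC)c(OC)c2)ccc1NC(=O)[C@@H](O)[C@H](N)CCc1ccccc1`: 700 nM

Compound 3 at 700 nM and compound 2 at 850 nM lie within the scatter of each other. Compound 1 at 1800 nM stands apart from compound 3, with a higher number beyond the scatter.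

Next is compound 4 `COc1cc(/C=C/C(=O)Nc2ccc(NC(=O)[C@@H](O)[C@H](N)CCc3ccccc3)c(C)c2)cc(OC)c1OC`, with methyl in place of methoxy on an aromatic carbon, ortho to a large group and meta to a large group: methyl in place of methoxy on an aromatic carbon.

Among the compounds with values here, the one measured step that bears on this carbon is a 1.2-fold lower number from compound 2 to compound 3 (0.08 log units; within the scatter), where methoxy replaces hydrogen. That step lies within the scatter, so exchanging this substituent has not yet moved the number in this assay. Compound 1 also carries a methyl but differs in more than one place, so it gives no clean comparison. No step beyond the scatter is expected, and no direction is favoured. The expected change is a 1.1-fold higher number from compound 3 to compound 4 (0.06 log units; within the scatter). The estimate for compound 4 is 800 nM, with an expected range of 350 nM to 1800 nM.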

Compound 4, concentration for 50% growth inhibition: 2300 nM
Compound 4: the middle estimate sits 2.9-fold (0.46 log units) below what was measured, outside the stated range (above it).
By their numbers in this assay, from the lowest: compounds 3 and 2 (each within the scatter of the next); then compounds 1 and 4 (each within the scatter of the next).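

In this assay this aromatic carbon, ortho to a large group and meta to a large group, does respond to its substituent: methyl in place of methoxy gives a 3.3-fold higher number from compound 3 to compound 4 (0.52 log units; beyond the scatter) and methyl in place of hydrogen gives a 2.7-fold higher number from compound 2 to compound 4 (0.43 log units; beyond the scatter) in the same direction. Within the data shown here, the earlier exchange here, methoxy in place of hydrogen, gave a 1.2-fold lower number from compound 2 to compound 3 (0.08 log units; within the scatter) and did not separate those two groups, so methyl is the first group at this carbon to stand apart, with a weaker inhibition of growth than either. No measurement at hand accounts for methyl parting from both methoxy and hydrogen.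

On these data alone, whether this loss belongs to methyl alone or also appears with ethyl, chlorine or an amine on this carbon stays open. Among these compounds, also open is whether the same exchange holds with the side chain of compound 1 in place of the one shared by compound 2, compound 3 and compound 4.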